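A few compounds are considered here, and "the series" means these few. Any claim that something is new, unique, unknown or untested is made for them only; others in the source may bear on it.

Of the compounds shown here, two have been measured in a functional assay on CHO cells for antagonist activity at sphingosine 1-phosphate receptor 2 (Homo sapiens), read by calcium flux; on this read-out lower numbers stand for stronger inhibition and higher numbers for weaker inhibition. Compound 1, `COc1ccc(Cl)cc1NC(=O)Cc1nn(CC(=O)O)c(=O)c2ccccc12`, is recorded only as a limit of this assay, > 1790 nM, and not as a number. Compound 2, `COC(C(=O)O)c1nn(Cc2cn3cc(OCC4CC4)c(Cl)cc3n2)c2ccccc2c1=O`, gives 23 nM in this assay. Compound 2 therefore holds the only numerical value among the two shown, and the limit of > 1790 nM in this assay, at which 1 of the 2 values shown sits, tells the rest of what is known.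

Compound 3, `CCC(C(=O)O)c1nn(Cc2cn3cc(OCC4CC4)c(Cl)cc3n2)c2ccccc2c1=O`, has not yet been measured. It differs from compound 2 by ethyl in place of methoxy on a saturated chain carbon bound to an aromatic carbon and a carbonyl carbon. Going by the values given here, no pair of measured compounds differing in one place is available to guide the size of this step, so no step beyond the usual scatter can be claimed in either direction from the data alone.

The expectation is that compound 3 will sit close to compound 2 in this assay, with a step of a 1.3-fold higher number from compound 2 to compound 3 (0.12 log units; within the scatter) estimated. Compound 3 is accordingly estimated at 30 nM in this assay, within a range from 8 nM to 110 nM.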

Compound 3, half-maximal inhibitory concentration: 5.6 nM
Beside the measured number, compound 3's estimate is 5.4-fold (0.73 log units) above it; measured number below the stated range.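

Going by these compounds alone, on the saturated chain carbon bound to an aromatic carbon and a carbonyl carbon, the choice of group clearly matters in this assay: ethyl in place of methoxy gives a 4.1-fold lower number from compound 2 to compound 3 (0.61 log units; beyond the scatter), and this is the first step between measured compounds that differ in one place. The change is small, with two heavy atoms leaving and two entering, yet it moves the read-out beyond the usual scatter, so this position responds to an exchange of this size. The hydrogen-bond acceptor that leaves with methoxy is also not needed for the value of compound 3, 5.6 nM, although no measurement shown bears on why ethyl gives the lower number.

This single step does not show whether the trend continues with a longer chain such as propyl, or whether a smaller group such as methyl or a hydroxyl group at the same place would keep the value of compound 3. It also leaves open how the other parts of the shared core, including the cyclopropylmethoxy group, contribute to the read-out.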